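The source may hold more compounds than are shown below. What is called first, only, known or untested is meant among the compounds shown, and "the series" means these compounds.

Compound 1 `CCOc1cc(C)c(-c2cccc(CNc3ccc(OCC(=O)O)c(F)c3)c2)c(C)c1`: 3.04
Compound 2 `CCOc1ccc(-c2cccc(CNc3ccc(OCC(=O)O)c(F)c3)c2)c(C)c1`: 2.83

Going by the values given here, in a physicochemical assay for lipophilicity, read by HPLC, in phosphate buffer, measured as octanol-water partition, at pH 7.4, tested at 100 uM (a higher number here means a more lipophilic compound, a lower number a more polar compound), compound 2 gives 2.83 and stands level, within the scatter, with the only other measured compound (a number 0.21 log units lower from compound 1 to compound 2 (within the scatter)). Compound 3 `COCCOc1ccc(-c2cccc(CNc3ccc(OCC(=O)O)c(F)c3)c2)c(C)c1` has not yet been measured. It differs from compound 2 by methoxy in place of hydrogen on a saturated chain carbon, two bonds along the chain from an oxygen on an aromatic ring, which turns ethoxy into 2-methoxyethoxy. Among the compounds with values here, the one measured step, hydrogen in place of methyl on an aromatic carbon, is a different change at a different place, so its size (a number 0.21 log units lower from compound 1 to compound 2 (within the scatter)) bears only loosely on this one. No measurement covers the new change, so its direction rests on judgement alone. A modest drop in this assay is expected, with an estimated step (a number 0.33 log units lower from compound 2 to compound 3 (beyond the scatter)). For compound 3 the estimate is 2.5 (expected range 2.15 to 2.85).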

Compound 3, distribution coefficient: 2.23
Compound 3: middle estimate off by 0.27 log units, on the high side; the measured number falls inside the stated range.
By their numbers in this assay, from the lowest: compound 3; then compounds 2 and 1 (each within the scatter of the next).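

In this assay, turning ethoxy into 2-methoxyethoxy gives a clear shift: a number 0.60 log units lower from compound 2 to compound 3 (beyond the scatter). This shows that a change on a saturated chain carbon, two bonds along the chain from an oxygen on an aromatic ring, can move this read-out beyond the scatter, which the earlier swap of hydrogen for methyl on an aromatic carbon did not do. Nothing measured here explains why the number moves this way.

The compounds shown leave open whether this step belongs to methoxy itself or whether a hydroxyl, an amine or a plain longer chain at the same place would give a similar one. They also leave open whether 2-methoxyethoxy would produce a step of the same size on the core of compound 1, which carries the extra methyl.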